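Side-chain steps and a para swap in the series

The source may hold more compounds than are shown below. What is called first, only, known or untested is meant among the compounds shown, and "the series" means these compounds.

Measured in a functional assay on PC-3 cells (Homo sapiens) for inhibition, read by MTT assay, with a stated time of 48 h; a higher number here means a weaker inhibitor, a lower number a stronger inhibitor:
- compound 1 `COc1ccc(-n2c(SCc3ccccc3)nnc2-c2cc(OC)c(OC)c(OC)c2)cc1`: 34100 nM
- compound 2 `COc1ccc(-n2c(SCC(=O)c3ccc4ccccc4c3)nnc2-c2cc(OC)c(OC)c(OC)c2)cc1`: > 60000 nM (a limit, not a number)
- compound 3 `COc1ccc(-n2c(SCC(=O)Nc3ccc(Cl)cc3)nnc2-c2cc(OC)c(OC)c(OC)c2)cc1`: 6290 nM

In this assay compound 1 gives 34100 nM, the higher of the two actual numbers. The nearest measured neighbour is reached by a 5.4-fold lower number from compound 1 to compound 3 (0.73 log units; beyond the scatter). The value of compound 2 is a limit of the assay.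

Compound 4 `COc1cc(-c2nnc(SCc3ccccc3)n2-c2ccc(N(C)C)cc2)cc(OC)c1OC` keeps the core and the benzyl sulfide side of compound 1 and changes the 4-methoxyphenyl to 4-(dimethylamino)phenyl: dimethylamino in place of methoxy on an aromatic carbon, para to a large group (dimethylamino in place of methoxy on an aromatic carbon).

Within the data shown here, none of the measured steps touches this place. All three change the group on the sulfur: an at least 1.7-fold higher number from compound 1 to compound 2 (0.24 log units; that floor lies within the scatter), a 5.4-fold lower number from compound 1 to compound 3 (0.73 log units; beyond the scatter) and an at least 9.5-fold lower number from compound 2 to compound 3 (0.97 log units; beyond the scatter). They show that this assay responds to changes at the sulfur side chain, but they give no size for a change on the 4-methoxyphenyl. With only compound 1 at 34100 nM as an anchor, no step beyond the scatter is expected, and the uncertainty stays wide in both directions.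

The estimated step is a 1.2-fold lower number from compound 1 to compound 4 (0.09 log units; within the scatter). For compound 4 the expected value is 28000 nM, with an estimated range from 10000 nM to 60000 nM.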

Compound 4, half-maximal inhibitory concentration: 55800 nM
Compound 4: the middle estimate sits 2.0-fold (0.30 log units) below what was measured; measured number inside the range.
By their numbers in this assay, from the lowest: compound 3; then compounds 1 and 4 (each within the scatter of the next). At a limit, above all of these: compound 2.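

Among these compounds, compound 4 gives the first size for a change on the 4-methoxyphenyl: in this assay, dimethylamino in place of methoxy on this aromatic carbon, para to a large group, gives a 1.6-fold higher number from compound 1 to compound 4 (0.21 log units; within the scatter) with the benzyl sulfide held fixed. At this one place, then, the exchange stays within the scatter, whereas a change on the sulfur side chain gives a 5.4-fold lower number from compound 1 to compound 3 (0.73 log units; beyond the scatter) and so lies beyond it. With compound 4 at 55800 nM, little room remains for reading any higher number at this place. The value of compound 2 is a limit and not a number: the limit of > 60000 nM in this assay, at which 1 of the 4 values shown sits.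

Still open, on these data alone, is whether the same exchange stays within the scatter on the (4-chlorophenyl)carbamoyl side chain of compound 3, which gives 6290 nM and offers far more room for a step in either direction. Also open, as far as these compounds go, is whether a different group at this place, such as a hydroxyl, a primary amine, a carboxylic acid or a chlorine atom, gives a step beyond the scatter on the benzyl sulfide of compound 1.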